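The source may hold more compounds than are shown below. What is called first, only, known or untested is meant among the compounds shown, and "the series" means these compounds.

In a physicochemical assay, read by spectrophotometry (on this read-out higher numbers stand for weaker inhibition and lower numbers for stronger inhibition), the measured compounds so far are:
- compound 1 `O=C1CSc2ccccc2N1Cc1cn(-c2cccc([N+](=O)[O-])c2)nn1` with 47.1 ug/mL
- compound 2 `O=C1CSc2ccccc2N1Cc1cn(Cc2cccc([N+](=O)[O-])c2)nn1` with 34.1 ug/mL

Compound 2 and compound 1 lie within the usual scatter of repeated measurements, so these numbers do not separate them. Going by the values given here, neither compound can be called the better inhibitor, and no pair measured so far differs in one place alone.

Compound 3 `O=C1CSc2ccccc2N1Cc1cn(Cc2ccc([N+](=O)[O-])cc2)nn1` has the same atoms as compound 2, joined differently: 4-nitrophenyl in place of 3-nitrophenyl on a saturated chain carbon bound to an aromatic nitrogen. Among the compounds with values here, with no measurement yet showing what such a swap does, no shift beyond the scatter is expected in this assay, in either direction. The expected size is a 1.1-fold higher number from compound 2 to compound 3 (0.02 log units; within the scatter), an estimate that stays within the scatter. For compound 3 the estimated value is 36 ug/mL (expected range 18 ug/mL to 72 ug/mL).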

Compound 3, half-maximal inhibitory concentration: 27.4 ug/mL
Compound 3: the middle estimate sits 1.3-fold (0.12 log units) above what was measured; measured number inside the range.
By their numbers in this assay, from the lowest: compounds 3, 2 and 1 (each within the scatter of the next).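

Going by these compounds alone, compound 2 and compound 3 form the first pair that differs in one place alone, so the series now has its first direct test of a single change: 4-nitrophenyl in place of 3-nitrophenyl on a saturated chain carbon bound to an aromatic nitrogen. In this assay, this swap gives a 1.2-fold lower number from compound 2 to compound 3 (0.10 log units; within the scatter), so the two compounds cannot be separated, and at this place the assay does not distinguish the 3-nitrophenyl group from the 4-nitrophenyl group. No independent measurement is available to explain these numbers.

The compounds shown leave open whether replacing the nitro group on this ring with an amine or a carboxylic acid would shift the number beyond the scatter. They also leave open what a longer chain at this place would do.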